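Propenyl to Propargyl on a Weakly Binding Core

The source may hold more compounds than are shown below. What is called first, only, known or untested is meant among the compounds shown, and "the series" means these compounds.

Compound 3 `C/C=C/CN1CCC(O)C(N2CCN(c3ccccc3)CC2)C1` carries a prop-1-en-1-yl group on a saturated chain carbon bound to an amine nitrogen in a ring. In an assay on PC-12 cells for displacement of a labelled ligand from vesicular acetylcholine transporter (Homo sapiens) (a higher number here means a weaker inhibitor, a lower number a stronger inhibitor), compound 3 gives only a limit of > 100 nM, not a number. Compound 1 `OC1CCN(Cc2ccc(Br)cc2)CC1N1CCN(c2ccccc2)CC1`, which bears 4-bromophenyl at the same place, is likewise reported only as a limit of > 100 nM in this assay. Compound 2 `CCN1CCC(O)C(N2CCN(c3ccccc3)CC2)C1`, with a methyl there, is reported in this assay only as a limit of > 1000 nM. All three values are limits, so the steps a step that the two limits leave unreadable from compound 1 to compound 2, a step that the two limits leave unreadable from compound 1 to compound 3 and a step that the two limits leave unreadable from compound 2 to compound 3 cannot be read in size or direction. Two of the values sit at the limit of > 100 nM in this assay, at which 2 of the 3 values shown sit, and one at the limit of > 1000 nM in this assay, at which 1 of the 3 values shown sits.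

Compound 4 `C#CCN1CCC(O)C(N2CCN(c3ccccc3)CC2)C1` differs from compound 3 by ethynyl in place of prop-1-en-1-yl on a saturated chain carbon bound to an amine nitrogen in a ring. None of the measured steps bears on this change with a readable size, and every analogue of the shared core shown here stops at a limit. The step from compound 3 to compound 4 is therefore expected to be a step that the limit leaves unreadable from compound 3 to compound 4, with no direction beyond the scatter supported by the data. Compound 4 is estimated to give 300 nM in this assay, with a range from 60 nM to 3000 nM.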

Compound 4, half-maximal inhibitory concentration: > 100 nM
Compound 4 was reported as a limit; the forecaster's own chance of this, stated with the estimate: 70%; the middle value does not contradict the limit.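

In this assay compound 4 gives > 100 nM, a limit and not a number. Its steps from compound 1, compound 2 and compound 3 cannot be read in size or direction, and most values shown share one limit: the limit of > 100 nM in this assay, at which 3 of the 4 values shown sit.

The compounds shown leave open how ethynyl, prop-1-en-1-yl, methyl and 4-bromophenyl at this place rank in this assay.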